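Swapping a dichlorophenyl for a dimethoxyphenyl on the ketone

This account rests on a few compounds, and the source may have more. Where it says the series, first, only, none or still open, it means among the compounds named here.

Three analogues sharing a core have been tested in a functional assay on NCI-H522 cells (Homo sapiens) for cytotoxicity, read by sulforhodamine B assay, with a stated time of 48 h, tested at 10 uM; on this read-out lower numbers stand for a stronger effect and higher numbers for a weaker effect at the one concentration tested. Compound 1, `COc1ccc(-c2cc(/C=C/C(=O)c3ccc(OC)c(OC)c3)[nH]n2)cc1`, gives -68%. Compound 2, `COc1cc(-c2cc(/C=C/C(=O)c3ccc(Cl)c(Cl)c3)[nH]n2)cc(OC)c1OC`, gives -72%, the second highest of the three numbers; its nearest neighbour is compound 1, whose number is within the usual scatter of it, while compound 3, `COc1ccc(-c2cc(/C=C/C(=O)c3ccc(N)cc3)[nH]n2)cc1OC`, gives -84%, a number lower than that of compound 2 by more than the scatter. Compound 4, `COc1ccc(C(=O)/C=C/c2cc(-c3cc(OC)c(OC)c(OC)c3)n[nH]2)cc1OC`, has not yet been measured in this assay. It differs from compound 2 in one place: 3,4-dimethoxyphenyl in place of 3,4-dichlorophenyl on a carbonyl carbon. Among the compounds with values here, no pair of measured compounds differing in exactly this way is available, so the effect of the change cannot be read off directly. Compound 1 carries the same 3,4-dimethoxyphenyl on its carbonyl carbon and gives -68%, a number within the scatter of compound 2. On that basis the step of a number 2 percentage points higher from compound 2 to compound 4 (within the scatter) is expected to be small, with no direction beyond the scatter. Compound 4 is therefore estimated at -70%, with a range from -85% to -55%.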

Compound 4, a percentage reported as activity, at one concentration (the size of the read-out at that concentration, not a potency): -95%
For compound 4 the middle estimate is 25 percentage points above the measured one; the whole stated range lies above it.
By their numbers in this assay, from the lowest: compound 4; then compound 3; then compounds 2 and 1 (each within the scatter of the next).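

In this assay the change from 3,4-dichlorophenyl to 3,4-dimethoxyphenyl on a carbonyl carbon can now be read directly, and it gives a number 23 percentage points lower from compound 2 to compound 4 (beyond the scatter) with the rest of the molecule unchanged. Within the data shown here, the group on this carbon therefore matters in the setting of compound 2, which the earlier compounds, each differing from the others in more than one place, could not show. Compound 1 carries the same 3,4-dimethoxyphenyl and gives -68% while compound 4 gives -95% so this group does not bring the lower number whatever else the molecule carries.

On these data alone, whether a hydroxyl, a fluorine or an unsubstituted phenyl on this carbonyl carbon would follow either group remains open. Nothing shown here accounts for the size of the step.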